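Three Compounds and an Amide Swap

This account rests on a few compounds, and the source may have more. Where it says the series, first, only, none or still open, it means among the compounds named here.

Three compounds were tested in an assay on isolated protein for inhibition of ribosomal protein S6 kinase beta-1 (Homo sapiens), read by HTRF, tested at 10 uM; a lower number here means less inhibition, a higher number more inhibition at the concentration tested (going by the name of the read-out). Compound 1 `Clc1ccc2sc(CN3CCN(c4ncnc5c4CN(Cc4ccccc4)CC5)CC3)cc2c1` gives 11% in this assay. Compound 2 `CN(CCCn1ccnc1)C(=O)[C@@H]1CCCN1c1nccc(Nc2ccccc2)n1` gives 6% in this assay. Compound 3 `Cc1cccc(Nc2ncnc3c2CN(C(=O)c2ccc(N(C)C)c4ccccc24)CC3)c1` gives 0% in this assay. All three numbers are low, and they sit within the usual scatter of one another: compound 2 stands a few points away from compound 1 on one side and from compound 3 on the other, neither gap being more than the scatter of repeated measurements allows, so no real ordering among the three can be read.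

Compound 4 `COC[C@@H]1CCCN1C(=O)[C@@H]1CCCN1c1nccc(Nc2ccccc2)n1` is the next compound to be measured. It is built from compound 2 by one change on the carbonyl carbon whose other neighbours are a saturated ring carbon: 2-(methoxymethyl)pyrrolidin-1-yl in place of (3-(1H-imidazol-1-yl)propyl)(methyl)amino on a carbonyl carbon. The group that leaves carries one five-membered aromatic ring with two hetero atoms; the group that enters carries one five-membered non-aromatic ring with one hetero atom and a defined stereocentre.

For the measured compounds named here, no pair of measured compounds differs in just one place, so no measured step guides this change. Given that compound 2 gives 6%, compound 4 is expected to stay low as well, and the step of a number 1 percentage points higher from compound 2 to compound 4 (within the scatter) is estimated to fall within the scatter rather than beyond it. The estimate for compound 4 is 7%, with a range from 0% to 20%.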

Compound 4, a percentage reported as inhibition, at one concentration (the size of the read-out at that concentration, not a potency): 8%
The estimate for compound 4 lay 1 percentage points below the measured number; low and high end bracket the measured number.
By their numbers in this assay, from the lowest: compounds 3, 2, 4 and 1 (each within the scatter of the next, the first and the last beyond it).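

On the carbonyl carbon, putting 2-(methoxymethyl)pyrrolidin-1-yl in place of (3-(1H-imidazol-1-yl)propyl)(methyl)amino gives a number 2 percentage points higher from compound 2 to compound 4 (within the scatter) in this assay at this position. The group that leaves carries a five-membered aromatic ring with two hetero atoms and the group that enters carries a five-membered non-aromatic ring with a defined stereocentre, yet the two compounds cannot be told apart, and both remain low at the concentration tested. No measurement at hand explains this result. Going by these compounds, whether a small group such as dimethylamino, or a longer chain ending in a morpholine, would read any differently on this carbonyl carbon remains open. So does the effect of the other stereoisomer of 2-(methoxymethyl)pyrrolidin-1-yl, or of a carboxylic acid in place of the whole amide.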